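A few compounds are considered here, and "the series" means these few. Any claim that something is new, unique, unknown or untested is made for them only; others in the source may bear on it.

Series notes. The shared core of compound 1 `O=C(O)c1cc(-c2ccc(-c3ccc(Cl)cc3Cl)cc2)n(-c2ccc(Cl)cc2Cl)n1` carries a 2,4-dichlorophenyl on the distal ring; in an assay on isolated protein for inhibition of methionine--tRNA ligase, cytoplasmic (Homo sapiens) (on this read-out lower numbers stand for stronger inhibition and higher numbers for weaker inhibition), compound 1 gives 11900 nM. Compound 2 `O=C(O)c1cc(-c2ccc(-c3ccc(F)cc3)cc2)n(-c2ccc(Cl)cc2Cl)n1` has 4-fluorophenyl in that position instead, and in this assay compound 2 gives 41300 nM. Compound 3 `O=C(O)c1cc(-c2ccc(-c3ccc(Cl)cc3Cl)cc2)nn1Cc1ccccn1` keeps the distal 2,4-dichlorophenyl but differs at the ring nitrogen; in this assay compound 3 gives 22300 nM. Compound 2 thus shows the highest of the three numbers, though its gap to compound 3 lies within the scatter, while the step of a 3.5-fold higher number from compound 1 to compound 2 (0.54 log units; beyond the scatter) is beyond it.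

The next compound is compound 4 `O=C(O)c1cc(-c2ccc(-c3ccccc3)cc2)n(-c2ccc(Cl)cc2Cl)n1`, where the change from compound 2 is hydrogen in place of fluoro on an aromatic carbon, on an aromatic carbon of a six-membered aromatic ring of carbon only, para to a large group. Among the compounds with values here, the only step that bears on it is the one from compound 1 to compound 2, in which trimming the halogen pattern on the same distal ring raised the number modestly. A smaller trimming is now at hand, so for compound 4 a further small rise in this assay is expected, possibly within the scatter, giving an estimated 1.3-fold higher number from compound 2 to compound 4 (0.12 log units; within the scatter). Compound 4 is accordingly estimated at 55000 nM, with a range from 25000 nM to 120000 nM.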

Compound 4, half-maximal inhibitory concentration: 44300 nM
Compound 4: the middle estimate sits 1.2-fold (0.09 log units) above what was measured; measured number inside the range.
By their numbers in this assay, from the lowest: compounds 1, 3, 2 and 4 (each within the scatter of the next, the first and the last beyond it).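

In this assay, hydrogen in place of fluoro, on an aromatic carbon para to a large group, gives a 1.1-fold higher number from compound 2 to compound 4 (0.03 log units; within the scatter) and so does not separate these two compounds. The step of a 3.7-fold higher number from compound 1 to compound 4 (0.57 log units; beyond the scatter) is beyond the scatter, so among these compounds the separation on this ring lies between the 2,4-dichlorophenyl on one side and the 4-fluorophenyl and phenyl on the other, and the fluoro itself plays no visible part. Nothing at hand accounts for either step.

Still open, on these data alone, is whether a single chloro on this ring would go with the lower number of compound 1 or with the higher numbers of compound 2 and compound 4. Also open, as far as these compounds go, is whether methoxy, trifluoromethyl or an amine at the same place would move the number beyond the scatter from that of compound 4.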